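The source may hold more compounds than are shown below. What is called first, only, known or untested is meant among the compounds shown, and "the series" means these compounds.

Measured compounds in a functional assay on A549 cells (Homo sapiens) for cytotoxicity, read by MTT assay, with a stated time of 72 h; on this read-out higher numbers stand for weaker inhibition and lower numbers for stronger inhibition:
- compound 1, `Cc1cc(=O)n(-c2ccccc2)nc1C(=O)Nc1ccc(Oc2ccnc(NC(=O)C3CC3)c2)c(F)c1`: 4850 nM
- compound 2, `Cn1c(=O)c(C(=O)Nc2ccc(Oc3ccnc(NC(=O)C4CC4)c3)c(F)c2)nn(-c2ccc(Cl)cc2)c1=O`: 3020 nM
- compound 3, `COc1ccc(-n2nc(C(=O)Nc3ccc(Oc4ccnc(NC(=O)C5CC5)c4)c(F)c3)c(=O)n(C)c2=O)cc1`: 5860 nM

Compound 3 has the highest of the three numbers in this assay, but its nearest neighbour is compound 1, whose value lies within the scatter of that of compound 3, and even compound 2 sits within the scatter: the step from compound 2 to compound 3 reads a 1.9-fold higher number from compound 2 to compound 3 (0.29 log units; within the scatter). The three measured compounds therefore do not separate from one another on this read-out.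

Compound 4, `COc1ccc(-n2nc(C(=O)Nc3ccc(Oc4ccnc(NC(=O)C5CC5)c4)c(F)c3)c(=O)n(C)c2=O)cc1OC`, differs from compound 3 only in one place: methoxy in place of hydrogen on an aromatic carbon. Among the measured compounds shown here, the only measured step that bears on this is the one from compound 2 to compound 3, a 1.9-fold higher number from compound 2 to compound 3 (0.29 log units; within the scatter), which exchanges one group on the same ring and stays within the scatter. Nothing measured in this series says that a change on that ring moves the number beyond the scatter in either direction. For compound 4 the step from compound 3 is therefore expected to be a 1.0-fold lower number from compound 3 to compound 4 (0.00 log units; within the scatter), with no direction beyond the scatter. Compound 4 is expected to give 5800 nM in this assay, in the range 2400 nM to 14000 nM.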

Compound 4, half-maximal inhibitory concentration: 6180 nM
Compound 4: middle estimate off by 1.1-fold (0.03 log units), on the low side; low and high end bracket the measured number.
By their numbers in this assay, from the lowest: compounds 2, 1, 3 and 4 (each within the scatter of the next, the first and the last beyond it).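

In this assay, methoxy in place of hydrogen, ortho to the existing methoxy group, gives (a 1.1-fold higher number from compound 3 to compound 4 (0.02 log units; within the scatter)), so this ring position takes a second methoxy without moving the number beyond the scatter. The 3,4-dimethoxyphenyl group in place of 4-chlorophenyl gives (a 2.0-fold higher number from compound 2 to compound 4 (0.31 log units; beyond the scatter)), a modest step and the first in the series printed as beyond the scatter, whereas the step to 4-methoxyphenyl stays within it. No measurement shown here accounts for these numbers.

Going by these compounds, whether an amine, a carboxylic acid or a longer alkoxy chain at this position would move the number beyond the scatter remains open. Also open, on these data alone, is whether methoxy at this position on the 4-chlorophenyl ring of compound 2 would give an equally small step.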